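Hydrogen in Place of Methoxy on an Indole Vinyl Sulfone

The source may hold more compounds than are shown below. What is called first, only, known or untested is meant among the compounds shown, and "the series" means these compounds.

Compound 1, `O=C(/C(=C\c1c(-c2ccccc2)[nH]c2ccccc12)S(=O)(=O)c1ccccc1)c1ccccc1`, gives 9000 nM in a functional assay on UACC-62 cells (Homo sapiens) for inhibition, read by sulforhodamine B assay, with a stated time of 48 h; a higher number here means a weaker inhibitor of growth, a lower number a stronger inhibitor of growth.
Compound 2, `COc1ccc2[nH]c(-c3ccccc3)c(/C=C(\C#N)S(=O)(=O)c3ccccc3)c2c1`, gives 3800 nM in this assay.

Compound 2 stands at the lowest of the two numbers; compound 1 sits beyond the scatter above it, yet the two differ in more than one place, so only their values can be set side by side. Compound 3, `N#C/C(=C\c1c(-c2ccccc2)[nH]c2ccccc12)S(=O)(=O)c1ccccc1`, is not yet measured. It differs from compound 2 by hydrogen in place of methoxy on an aromatic carbon. Going by the values given here, no measured pair isolates this change, so no step beyond the scatter is expected, if anything a slight move toward weaker inhibition. Compound 3 is therefore expected to give about 5000 nM, within a range from 2000 nM to 12000 nM. The step this estimate means, a 1.3-fold higher number from compound 2 to compound 3 (0.12 log units; within the scatter), is expected to stay within the scatter.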

Compound 3, concentration for 50% growth inhibition: 2600 nM
Beside the measured number, compound 3's estimate is 1.9-fold (0.28 log units) above it; the measured number falls inside the stated range.
By their numbers in this assay, from the lowest: compounds 3 and 2 (each within the scatter of the next); then compound 1.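

With hydrogen in place of methoxy on the aromatic carbon, this assay shows a 1.5-fold lower number from compound 2 to compound 3 (0.16 log units; within the scatter) for this single change, so the methoxy group is not needed to hold the number in this pair. Cyano in place of benzoyl on the double-bonded chain carbon gives a 3.5-fold lower number from compound 1 to compound 3 (0.54 log units; beyond the scatter) as a modest step, now isolated at one place. Nothing at hand accounts for either step.

The compounds shown leave open whether an amine or a carboxylic acid on that aromatic carbon would stay within the scatter of compound 3. Also open, from the compounds shown here alone, is how an amide on the chain carbon would compare with cyano.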